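Adding an Isobutyl Group to a Reductase Inhibitor

This account rests on a few compounds, and the source may have more. Where it says the series, first, only, none or still open, it means among the compounds named here.

Of the compounds shown here, three have been measured in an assay on isolated protein for inhibition of steroid 5-alpha-reductase (Rattus norvegicus); on this read-out lower numbers stand for stronger inhibition and higher numbers for weaker inhibition. Compound 1, `COc1ccccc1N1CCN(CCCOc2ccc(C(=O)Nc3ccccc3OCCCC(=O)O)cc2)CC1`, gives 41000 nM. Compound 2, `COc1ccccc1N1CCN(CCCCCCOc2ccc(C(=O)Nc3ccccc3OCCCC(=O)O)cc2)CC1`, gives 9500 nM. Compound 3, `COc1ccccc1N1CCN(CCC(Oc2ccc(NC(=O)c3ccccc3OCCCC(=O)O)cc2)c2ccccc2)CC1`, gives 730 nM. Compound 3 therefore stands lowest of the three and is the strongest inhibitor here: its nearest neighbour, compound 2, shows a markedly higher number, and compound 1 lies further away still, both gaps well beyond the usual scatter.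

The next compound, compound 4, `COc1ccccc1N1CCN(CCC(Oc2ccc(NC(=O)c3ccccc3OCCCC(=O)O)cc2)c2ccc(CC(C)C)cc2)CC1`, has not yet been measured. It differs from compound 3 in one place: isobutyl in place of hydrogen on an aromatic carbon. Seen one bond further out, a phenyl becomes a 4-isobutylphenyl. Going by the values given here, no measured pair among the three compounds mirrors this change, so no step of this kind is on record to guide the prediction.

The expectation for compound 4 is a step that stays within the scatter or shows only a small gain, with the step from compound 3 to compound 4 estimated at a 1.5-fold lower number from compound 3 to compound 4 (0.16 log units; within the scatter). In this assay compound 4 is estimated to give about 500 nM, with a range from 150 nM to 1600 nM.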

Compound 4, half-maximal inhibitory concentration: 96 nM
Estimate against measurement, compound 4: 5.2-fold (0.72 log units) above; measured number outside the range, below it.
By their numbers in this assay, from the lowest: compound 4; then compound 3; then compound 2; then compound 1.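

In this assay, the ring carbon para to a large group on the phenyl of compound 3 proves to be a place where a change can move the number: isobutyl in place of hydrogen gives a 7.6-fold lower number from compound 3 to compound 4 (0.88 log units; beyond the scatter) and so lies beyond the usual scatter. Going by these compounds alone, this is the first step between two compounds that differ in one place, since no earlier pair could show what a single change does. The group that enters is carbon only, with no ring, no hydrogen-bond donors or acceptors and no net charge, so a step of this size at this place requires none of these features.

No measurement at hand bears on why the step is this large. From the compounds shown here alone, it also remains open whether the branched isobutyl matters or any carbon chain would serve, which a methyl, a tert-butyl or a longer straight chain on the same carbon would test, and whether a hydroxyl or an amine there would move the number in the same direction.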